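Chain extension in the hydroxamic acid series

This account rests on a few compounds, and the source may have more. Where it says the series, first, only, none or still open, it means among the compounds named here.

- compound 1 `O=C(CCCCCOC(=O)c1ccc2c(c1)no[n+]2[O-])NO`: 11600 nM
- compound 2 `O=C(CCCCCCOC(=O)c1ccc2c(c1)no[n+]2[O-])NO`: 1260 nM

In a functional assay on HEL cells (Homo sapiens) for inhibition, read by MTT assay, with a stated time of 48 h (a higher number here means a weaker inhibitor, a lower number a stronger inhibitor), compound 2 has the lower of the two numbers, at 1260 nM. Compound 3 `O=C(CCCCCCCOC(=O)c1ccc2c(c1)no[n+]2[O-])NO` differs from it as follows: (hydroxycarbamoyl)methyl in place of hydroxycarbamoyl on a saturated chain carbon, six bonds along the chain from an oxygen next to a carbonyl group. Within the data shown here, the only measured step that bears on this is the same change made five bonds along the chain from an oxygen next to a carbonyl group, a 9.2-fold lower number from compound 1 to compound 2 (0.96 log units; beyond the scatter). One step does not establish a trend, so a further fall in this assay is expected, but a smaller one. The expected step is a 2.3-fold lower number from compound 2 to compound 3 (0.36 log units; beyond the scatter). Compound 3 is estimated at 550 nM, with an expected range of 130 nM to 2200 nM.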

Compound 3, half-maximal inhibitory concentration: 1500 nM
Compound 3: the middle estimate sits 2.7-fold (0.44 log units) below what was measured, and the stated range covers the measured number.
By their numbers in this assay, from the lowest: compounds 2 and 3 (each within the scatter of the next); then compound 1.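

In this assay the same change made six bonds along the chain from an oxygen next to a carbonyl group gives a 1.2-fold higher number from compound 2 to compound 3 (0.08 log units; within the scatter), so the fall seen one bond earlier does not repeat at this place. Compound 3 nevertheless retains a 7.7-fold lower number from compound 1 to compound 3 (0.89 log units; beyond the scatter), which places the sensitivity to chain length in this series at the step from compound 1 to compound 2. No measured evidence explains this flattening. On these data alone, whether a longer chain holds this level or loses it remains open, as does the effect of a carboxylic acid in place of hydroxycarbamoyl.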